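Changing the side chain on a cytotoxicity limit

A few compounds are considered here, and "the series" means these few. Any claim that something is new, unique, unknown or untested is made for them only; others in the source may bear on it.

Compound 3 `CC(C)C1(Cc2ccccc2)OS(=O)(=O)C=C1OCc1ccccc1` was tested in an ADME assay on HEL cells (Homo sapiens) for cytotoxicity, with a stated time of 3 days; on this read-out higher numbers stand for lower toxicity in this test and lower numbers for higher toxicity in this test. In this assay compound 3 reaches only the limit >= 80000 nM, so no number is known for it. Compound 2 `CC(C)CC1(Cc2ccccc2)OS(=O)(=O)C=C1OCc1ccccc1` also sits at a limit, >= 80000 nM. The step that the two limits leave unreadable from compound 2 to compound 3 is therefore unreadable. Compound 1 `CCC1(Cc2ccccc2)OS(=O)(=O)C=C1OCc1ccccc1Cl` reaches the limit >= 20000 nM. Within the data shown here, two of the three values sit at the limit of >= 80000 nM in this assay, at which 2 of the 3 values shown sit, and one at the limit of >= 20000 nM in this assay, at which 1 of the 3 values shown sits, so no measured step yields a readable size.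

Compound 4 `CCCC1(Cc2ccccc2)OS(=O)(=O)C=C1OCc1ccccc1` is not yet measured. It differs from compound 3 by propyl in place of isopropyl on a saturated ring carbon. Among the measured compounds shown here, the only measured step at a saturated ring carbon, a step that the two limits leave unreadable from compound 2 to compound 3, lies between two limits and gives no size. No step beyond the usual scatter is therefore expected in this assay, and compound 4 is expected to reach the same limit as compound 3. The estimate for compound 4 is 80000 nM, with an expected range from 40000 nM to 160000 nM, meaning an expected step of a number no higher from compound 3 to compound 4 (the limit leaves the size open).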

Compound 4, minimum cytotoxic concentration: >= 400000 nM
Compound 4 gave a limit, no number (the forecaster's own chance of this, stated with the estimate: 85%); at least 5.0-fold (0.69 log units) between middle value and limit.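

In this assay compound 4 reaches only the limit >= 400000 nM and no number. Compound 2 and compound 3 also sit at limits, so the steps among these three compounds cannot be read. From the compounds shown here alone, whether changing this side chain shifts the cytotoxic concentration at all stays open.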